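This account rests on a few compounds, and the source may have more. Where it says the series, first, only, none or still open, it means among the compounds named here.

Measured compounds:
Compound 1 `COc1cc(-c2nnc(S(=O)(=O)C3CCC3)[nH]2)ccc1-c1cnc(OCC(C)C)c(Cl)c1`: 61 uL/min
Compound 2 `COc1cc(-c2nnc(S(=O)(=O)C3CCC3)[nH]2)c(F)cc1-c1cnc(OCC(C)C)c(Cl)c1`: 27 uL/min
Compound 3 `O=S(=O)(CC1CC1)c1nnc(-c2cc(F)c(-c3cnc(Oc4ccc(F)cc4Cl)c(Cl)c3)cc2F)[nH]1`: 53 uL/min

In an ADME assay on microsomes from liver (Rattus norvegicus) for metabolic stability (on this read-out lower numbers stand for slow clearance and higher numbers for fast clearance), compound 1 gives the highest of the three numbers; the gap to compound 3 lies within the scatter, whereas compound 2 sits beyond it, as the step of a 2.3-fold lower number from compound 1 to compound 2 (0.35 log units; beyond the scatter) shows. Compound 4 `COc1cc(-c2nnc(S(=O)(=O)N3CCC3)[nH]2)ccc1-c1cnc(OCC(C)C)c(Cl)c1` is not yet measured. It differs from compound 1 in one place: azetidin-1-yl in place of cyclobutyl on a sulfonyl sulfur. Within the data shown here, no measured step touches the sulfonyl substituent; the only measured step concerns fluoro in place of hydrogen on an aromatic carbon and therefore does not bear on this change. A step beyond the scatter in this assay is not expected in either direction, so the estimate for compound 4 is 50 uL/min, range 25 uL/min to 110 uL/min, meaning an expected step of a 1.2-fold lower number from compound 1 to compound 4 (0.09 log units; within the scatter).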

Compound 4, intrinsic clearance in a liver preparation (reported as CLH), per the amount of preparation that the assay uses: 170 uL/min
Beside the measured number, compound 4's estimate is 3.4-fold (0.53 log units) below it, and the stated range ends below it.
By their numbers in this assay, from the lowest: compounds 2, 3 and 1 (each within the scatter of the next, the first and the last beyond it); then compound 4.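

The sulfonyl substituent is a position that moves the read-out in this assay: azetidin-1-yl in place of cyclobutyl on a sulfonyl sulfur gives a 2.8-fold higher number from compound 1 to compound 4 (0.45 log units; beyond the scatter). Both groups are four-membered non-aromatic rings, so a change of ring atoms alone, with a nitrogen entering the ring and bonding to the sulfonyl sulfur, is enough for a step beyond the scatter. Nothing available accounts for the direction of this step.

Going by these compounds, whether fluoro in place of hydrogen on an aromatic carbon would lower the number for compound 4 remains open. So does the reading for an open-chain dimethylamino group or a morpholin-4-yl ring on the sulfonyl sulfur.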